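This account rests on a few compounds, and the source may have more. Where it says the series, first, only, none or still open, it means among the compounds named here.

Four compounds share one core and differ only in the group on the sulfonamide nitrogen. Compound 1 `CC(=O)NS(=O)(=O)c1ccc(N/C(S)=N\c2ccnc3cc(C(F)(F)F)ccc23)cc1` and compound 2 `N=C(N)NS(=O)(=O)c1ccc(N/C(S)=N\c2ccnc3cc(C(F)(F)F)ccc23)cc1` both carry a short, open-chain group there, compound 3 `Cc1noc(NS(=O)(=O)c2ccc(N/C(S)=N\c3ccnc4cc(C(F)(F)F)ccc34)cc2)c1C` carries a five-membered aromatic ring, and compound 4 `Cc1ccnc(NS(=O)(=O)c2ccc(N/C(S)=N\c3ccnc4cc(C(F)(F)F)ccc34)cc2)n1` carries a six-membered one. In a functional assay on HeLa cells (Homo sapiens) for antiproliferative activity, read by sulforhodamine B assay, with a stated time of 48 h (a lower number here means a stronger inhibitor, a higher number a weaker inhibitor), compound 1 gives 37600 nM, and compound 2 gives 23900 nM; the change at this position gives a 1.6-fold lower number from compound 1 to compound 2 (0.20 log units; within the scatter). Within the data shown here, compound 3 stands apart from these two numbers: in this assay compound 3 was reported as "not active" (no number reported), without a number, so no step from it can be measured. The move to compound 4 is 4-methylpyrimidin-2-yl in place of 3,4-dimethyl-1,2-oxazol-5-yl on a sulfonamide nitrogen. Among the measured compounds shown here, the only measured step, that from compound 1 to compound 2, concerns the same position and stayed within the scatter, so it offers little guidance beyond showing that this series is weak throughout. Compound 4 is therefore expected to remain weak in this assay, estimated at 40000 nM with a range from 15000 nM to 120000 nM, and a fair chance that only a limit is reported.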

Compound 4, half-maximal inhibitory concentration: 31000 nM
Beside the measured number, compound 4's estimate is 1.3-fold (0.11 log units) above it; the range from low to high includes it.
By their numbers in this assay, from the lowest: compounds 2, 4 and 1 (each within the scatter of the next).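

In this assay, replacing a short open-chain group on the sulfonamide nitrogen with 4-methylpyrimidin-2-yl, a six-membered aromatic ring, leaves the number within the scatter, both for a 1.3-fold higher number from compound 2 to compound 4 (0.11 log units; within the scatter) and for a 1.2-fold lower number from compound 1 to compound 4 (0.08 log units; within the scatter). An aromatic ring at this position is therefore compatible with a measurable number, although compound 3, with 3,4-dimethyl-1,2-oxazol-5-yl, has none, so the step from compound 3 to compound 4 cannot be read. No evidence is available to explain the difference between the two rings.

The compounds shown leave open whether a free amine, a carboxylic acid or a longer alkyl chain on this nitrogen would shift the number beyond the scatter. They also leave open whether the pyrimidine without its methyl group would behave like compound 4.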